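Ether-side aryl variation toward compound 4

The compounds below may be only part of what the source reports. "The series", "measured", "known", "first", "only" and "open" are said of these compounds alone.

Measured so far in a functional assay on A549 cells (Homo sapiens) for cytotoxicity, read by MTT assay, with a stated time of 72 h; on this read-out higher numbers stand for weaker inhibition and lower numbers for stronger inhibition:

compound 1, `CN1CCN(CCCCOc2c(OCc3ccc(C#N)cc3)cc(O)c3c(=O)cc(-c4ccccc4)oc23)CC1`, gives 2140 nM
compound 2, `CN1CCN(CCCCOc2c(OCc3ccco3)cc(O)c3c(=O)cc(-c4ccccc4)oc23)CC1`, gives 3600 nM
compound 3, `CN1CCN(CCCCOc2c(OCc3cccs3)cc(O)c3c(=O)cc(-c4ccccc4)oc23)CC1`, gives 2100 nM

The three compounds share one core and differ only in the aryl group on the saturated chain carbon bound to an oxygen on an aromatic ring. Compound 3 stands within the scatter of both neighbours: a 1.0-fold lower number from compound 1 to compound 3 (0.01 log units; within the scatter) and a 1.7-fold lower number from compound 2 to compound 3 (0.23 log units; within the scatter), and the remaining pair, a 1.7-fold higher number from compound 1 to compound 2 (0.23 log units; within the scatter), is no larger. Nothing in this set moves the number beyond repeat-measurement noise.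

Compound 4, `CN1CCN(CCCCOc2c(OCc3nc4ccccc4s3)cc(O)c3c(=O)cc(-c4ccccc4)oc23)CC1`, continues the same variation: 1,3-benzothiazol-2-yl in place of thiophen-2-yl on a saturated chain carbon bound to an oxygen on an aromatic ring. All three measured steps bear on it in that they exchange one aryl group for another at this position, and each stayed within the scatter. A bicyclic group with two hetero atoms has not yet been tried here, so the range is kept wide, but no direction is indicated by the data. For compound 4 the expected outcome in this assay is a step of a 1.0-fold higher number from compound 3 to compound 4 (0.02 log units; within the scatter), that is, essentially no change beyond the scatter. The estimate for compound 4 is 2200 nM, with a range from 900 nM to 5500 nM.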

Compound 4, half-maximal inhibitory concentration: 1060 nM
Beside the measured number, compound 4's estimate is 2.1-fold (0.32 log units) above it, and the stated range covers the measured number.
By their numbers in this assay, from the lowest: compounds 4, 3, 1 and 2 (each within the scatter of the next, the first and the last beyond it).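

In this assay, among the compounds shown here, the 1,3-benzothiazol-2-yl group is the first at this place, on a saturated chain carbon bound to an oxygen on an aromatic ring, to give steps that lie beyond the scatter: a 3.4-fold lower number from compound 2 to compound 4 (0.53 log units; beyond the scatter) and a 2.0-fold lower number from compound 1 to compound 4 (0.31 log units; beyond the scatter) are both modest, whereas no step among compound 1, compound 2 and compound 3 left the scatter. Against thiophen-2-yl the exchange stays within the scatter at a 2.0-fold lower number from compound 3 to compound 4 (0.30 log units; within the scatter) and so cannot be read as a real change, which means the position is shown to respond to the aryl group only when 1,3-benzothiazol-2-yl is set against furan-2-yl or 4-cyanophenyl. No measurement here accounts for these differences.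

The compounds shown leave open whether the six-membered aromatic ring of carbon only or the second hetero atom of the five-membered ring carries the difference, and a benzothiophen-2-yl or a 1,3-thiazol-2-yl group at this place would separate the two. Also open, going by these compounds, is how a quinolin-2-yl group, with its larger ring pair, would read in this assay against compound 4.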